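The source may hold more compounds than are shown below. What is called first, only, known or untested is meant among the compounds shown, and "the series" means these compounds.

Working notes on the series.

Of the compounds shown here, two have been measured. Compound 1 `CCCCC(=O)N1CCN(c2nc(=O)c3cc(C(F)(F)F)cc([N+](=O)[O-])c3s2)CC1` gives 42.5 ug/mL in a physicochemical assay for solubility, read by HPLC; on this read-out higher numbers stand for higher solubility and lower numbers for lower solubility. Among the compounds with values here, compound 2 `O=C(C1CCCCC1)N1CCN(c2nc(=O)c3cc(C(F)(F)F)cc([N+](=O)[O-])c3s2)CC1` gives 3.24 ug/mL in this assay and stands lowest of the two numbers; its nearest neighbour is compound 1, and the only measured step that connects them, a 13-fold lower number from compound 1 to compound 2 (1.12 log units; beyond the scatter), is large and beyond the scatter, with cyclohexyl in place of butyl on a carbonyl carbon.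

Compound 3 `CCC(=O)N1CCN(c2nc(=O)c3cc(C(F)(F)F)cc([N+](=O)[O-])c3s2)CC1` has not yet been measured. It differs from compound 2 in one place: ethyl in place of cyclohexyl on a carbonyl carbon. Within the data shown here, the one measured step bears directly on this change, since a 13-fold lower number from compound 1 to compound 2 (1.12 log units; beyond the scatter) shows what removing a butyl for a cyclohexyl on the same carbonyl carbon did; removing the cyclohexyl for an ethyl runs the other way and goes further than butyl. For compound 3 a large rise, a 25-fold higher number from compound 2 to compound 3 (1.39 log units; beyond the scatter), is therefore expected. Compound 3 is estimated at 80 ug/mL, within 25 ug/mL to 250 ug/mL.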

Compound 3, solubility: 3.29 ug/mL
Estimate against measurement, compound 3: 24-fold (1.39 log units) above; measured number below the stated range.
By their numbers in this assay, from the lowest: compounds 2 and 3 (each within the scatter of the next); then compound 1.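

In this assay the step of a 1.0-fold higher number from compound 2 to compound 3 (0.01 log units; within the scatter) means that ethyl and cyclohexyl on this carbonyl carbon cannot be told apart, so the earlier drop on going from butyl to cyclohexyl was not a matter of the ring alone. The step of a 13-fold lower number from compound 1 to compound 3 (1.11 log units; beyond the scatter) shows that the open chain itself matters: butyl and ethyl, both without a ring, stand well apart. Group size therefore gives no ordering at this position, with compound 1 standing alone against compounds 2 and 3, which stay level.

From the compounds shown here alone, whether propyl, pentyl or a longer chain, or an amine or a carboxylic acid on the chain, would side with compound 1 or with compounds 2 and 3 remains open. Nothing at hand speaks to the origin of this pattern.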